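Amide substituent changes on the shared core: compound 4

The compounds below may be only part of what the source reports. "The series", "measured", "known", "first", "only" and "open" are said of these compounds alone.

Measured so far:
compound 1 `COc1cc(CC(C)C(=O)N2CCN(c3ccc(C(F)(F)F)cc3[C@@H](N)CC(C)C)CC2)ccc1Cl` 230 nM
compound 2 `CC(C)C[C@H](N)c1cc(C(F)(F)F)ccc1N1CCN(C(=O)COc2cccc(Cl)c2)CC1` 2600 nM
compound 3 `Cc1cc(CC(C)C(=O)N2CCN(c3ccc(C(F)(F)F)cc3[C@@H](N)CC(C)C)CC2)ccc1Cl` 71 nM

Three compounds share the core and differ only in the group on the amide carbonyl carbon. In an assay on HEK293 cells for displacement of a labelled ligand from Melanocortin receptor 4 (Homo sapiens) (on this read-out lower numbers stand for stronger inhibition and higher numbers for weaker inhibition), compound 3 gives the lowest number of the three: the nearest is compound 1 with a 3.2-fold lower number from compound 1 to compound 3 (0.51 log units; beyond the scatter) reversed, the furthest compound 2 with a 37-fold lower number from compound 2 to compound 3 (1.56 log units; beyond the scatter). The step from compound 1 to compound 2, an 11-fold higher number from compound 1 to compound 2 (1.05 log units; beyond the scatter), shows that exchanging the whole carbonyl substituent moves the number a long way.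

Compound 4 `CC(C)C[C@H](N)c1cc(C(F)(F)F)ccc1N1CCN(C(=O)CCC(=O)c2ccc(Cl)cc2)CC1` is the next exchange at that position: 2-((4-chlorophenyl)carbonyl)ethyl in place of 1-(4-chloro-3-methylbenzyl)ethyl on a carbonyl carbon. Among the measured compounds shown here, the steps that bear on it are the two full-substituent exchanges, a 37-fold lower number from compound 2 to compound 3 (1.56 log units; beyond the scatter) and an 11-fold higher number from compound 1 to compound 2 (1.05 log units; beyond the scatter), both large, while the small ring-substituent change a 3.2-fold lower number from compound 1 to compound 3 (0.51 log units; beyond the scatter) was modest. Compound 4 keeps a ring carrying chlorine but, like compound 2, brings an oxygen into the linker, and compound 2 gave 2600 nM. For the measured compounds named here, a step upward from compound 3, less than the one seen for compound 2, is therefore expected: a 5.6-fold higher number from compound 3 to compound 4 (0.75 log units; beyond the scatter). Compound 4 is estimated at 400 nM, in the range 100 nM to 1600 nM.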

Compound 4, inhibition constant: 820 nM
Estimate against measurement, compound 4: 2.1-fold (0.31 log units) below; the range from low to high includes it.
By their numbers in this assay, from the lowest: compound 3; then compound 1; then compound 4; then compound 2.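

In this assay, the 2-((4-chlorophenyl)carbonyl)ethyl group gives a 12-fold higher number from compound 3 to compound 4 (1.06 log units; beyond the scatter) and a 3.6-fold higher number from compound 1 to compound 4 (0.55 log units; beyond the scatter), but also a 3.2-fold lower number from compound 2 to compound 4 (0.50 log units; beyond the scatter), so a chain with a carbonyl in the linker is not equivalent to the (3-chlorophenoxy)methyl group at this place. Among the four compounds, both 1-(benzyl)ethyl substituents give lower numbers than both substituents with oxygen in the linker, and no compound shown goes against this. Nothing available accounts for these differences.

Going by these compounds, the step from compound 3 changes the ring methyl, the chain branch and the carbonyl together, so the share of each remains open. A hydroxyl in place of the ketone carbonyl, or a plain 3-(4-chlorophenyl)propyl chain, would separate the contribution of that carbonyl from that of the chain.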